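Notes on a nitro substitution in a small amine set

The compounds below may be only part of what the source reports. "The series", "measured", "known", "first", "only" and "open" are said of these compounds alone.

The three measured compounds are read in a functional assay on L929 cells (Mus musculus) for inhibition, read by MTT assay, with a stated time of 5 days; on this read-out lower numbers stand for stronger inhibition and higher numbers for weaker inhibition. Compound 2 `COc1ccc(N(Cc2ccccc2)Cc2ccccc2)cc1` gives 12 ug/mL in this assay. Compound 3 `COc1ccc(NCc2ccccc2)cc1` gives 30 ug/mL in this assay, the step being a 2.5-fold higher number from compound 2 to compound 3 (0.40 log units; beyond the scatter). Compound 1 `COc1ccc(N(Cc2ccccc2)Cc2ccc([N+](=O)[O-])cc2)cc1` gives only > 40 ug/mL in this assay, which is a limit of the assay and not a number. The step of an at least 3.3-fold higher number from compound 2 to compound 1 (0.52 log units; beyond the scatter) therefore rests on the limit of > 40 ug/mL in this assay, at which 1 of the 3 values shown sits, and is bounded from below only.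

The change from compound 2 to compound 1 is nitro in place of hydrogen on an aromatic carbon. Compound 4 `COc1ccc(NCc2ccc([N+](=O)[O-])cc2)cc1` is not yet measured; it arises from compound 3 by the same change, (nitro in place of hydrogen on an aromatic carbon), which occurs two times in the set. The cores of compound 3 and compound 2 differ by hydrogen in place of benzyl on a nitrogen on an aromatic ring.

Compound 3 starts higher than compound 2, and the step from compound 3 to compound 4 is expected to be about a 2.7-fold higher number from compound 3 to compound 4 (0.43 log units; beyond the scatter), resting on compound 2 and compound 1 because an at least 3.3-fold higher number from compound 2 to compound 1 (0.52 log units; beyond the scatter) was seen for the same change. Compound 4 is expected near 80 ug/mL in this assay, most probably reported as a limit again.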

Compound 4, half-maximal inhibitory concentration: > 40 ug/mL
Compound 4 ended at the assay's limit; the forecaster's own chance of this, stated with the estimate: 80%; the middle value is on the limit's open side.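

Carried to the core of compound 3, nitro in place of hydrogen on an aromatic carbon gives in this assay an at least 1.3-fold higher number from compound 3 to compound 4 (0.12 log units; that floor lies within the scatter); this agrees in direction with the step on the core of compound 2, but the floor alone does not establish a real step on this second core. Set beside the earlier step, the result shows no demonstrated difference between the two cores, and it does not show that the change carries over with the same size: the same change on two cores in this assay, an at least 3.3-fold higher number (0.52 log units; beyond the scatter) from compound 2 to compound 1 and an at least 1.3-fold higher number (0.12 log units; that floor lies within the scatter) from compound 3 to compound 4; the limit leaves it open whether they differ Compound 1 and compound 4 both stand at a limit of the assay and not at a number, and the step between them cannot be read: the limit of > 40 ug/mL in this assay, at which 2 of the 4 values shown sit.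

Going by these compounds, the size of the nitro step on either core remains open. Also open, on these data alone, is whether an amine or a carboxylic acid in place of the nitro, or a longer chain in place of the benzyl on the nitrogen, would shift the number in this assay in the same direction.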